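Cytotoxicity notes on a shared-core series, Vero cells

The compounds below may be only part of what the source reports. "The series", "measured", "known", "first", "only" and "open" are said of these compounds alone.

Measured compounds in an ADME assay on Vero cells (Chlorocebus sabaeus) for cytotoxicity, read by MTT assay, with a stated time of 48 h; on this read-out higher numbers stand for weaker inhibition and lower numbers for stronger inhibition:
Compound 1 `COc1ccc(CN(C)c2nc(=O)c3cc(C(F)(F)F)cc([N+](=O)[O-])c3o2)cc1OC` gives 9.46 ug/mL in this assay.
Compound 2 `CN(Cc1ccccc1)c1nc(=O)c2cc(C(F)(F)F)cc([N+](=O)[O-])c2o1` gives 3.84 ug/mL in this assay.
Compound 3 `CN(Cc1ccc2c(c1)OCCO2)c1nc(=O)c2cc(C(F)(F)F)cc([N+](=O)[O-])c2o1` gives 9.27 ug/mL in this assay.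

Compound 2 stands lowest of the three; a 2.5-fold lower number from compound 1 to compound 2 (0.39 log units; beyond the scatter) and a 2.4-fold higher number from compound 2 to compound 3 (0.38 log units; beyond the scatter) are both modest, while a 1.0-fold lower number from compound 1 to compound 3 (0.01 log units; within the scatter) is within the scatter. Compound 4 `O=c1nc(NC2CCCCC2)oc2c([N+](=O)[O-])cc(C(F)(F)F)cc12` is unmeasured. The change is cyclohexylamino in place of benzyl(methyl)amino on an aromatic carbon. Going by the values given here, no measured step alters the benzyl(methyl)amino group itself; the three steps only vary the aryl on the saturated chain carbon, and those gave at most modest steps in this assay. A step of similar size or none beyond the scatter is therefore expected, direction uncertain. Compound 4 is estimated at 5.5 ug/mL, range 2 ug/mL to 14 ug/mL, an expected 1.4-fold higher number from compound 2 to compound 4 (0.16 log units; within the scatter).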

Compound 4, half-maximal inhibitory concentration: 5.39 ug/mL
For compound 4 the middle estimate is 1.0-fold (0.01 log units) above the measured one; the measured number falls inside the stated range.
By their numbers in this assay, from the lowest: compounds 2, 4, 3 and 1 (each within the scatter of the next, the first and the last beyond it).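

Earlier steps varied only the aryl on the saturated chain carbon; here the whole amino group on the aromatic carbon changes, and in this assay cyclohexylamino in place of benzyl(methyl)amino gives a 1.4-fold higher number from compound 2 to compound 4 (0.15 log units; within the scatter). At this position, then, a non-aromatic carbon ring and a hydrogen-bond donor on the entering group go with no step beyond the scatter. No supporting measurement is available to explain this result.

Open, going by these compounds, is whether an open-chain amine such as diethylamino, or morpholine bound through its nitrogen, would stay equally close at this carbon.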